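The source may report more compounds than this note shows. Statements on the series, on what has been measured and on what is new or still open speak of the compounds shown alone.

Compound 1 `CCCCCCCCc1ccc(OCC(=O)Cn2nnnc2C)cc1` gives 41 nM in an assay on microsomes from brain for inhibition of Fatty-acid amide hydrolase 1 (Rattus norvegicus), read by fluorescence and HPLC, with a stated time of 60 min; a higher number here means a weaker inhibitor, a lower number a stronger inhibitor.
Compound 2 `CCCCCCCCc1ccc(OCC(=O)Cn2nnnc2-c2cccs2)cc1` gives 55 nM in this assay.
Compound 3 `CCCCCCCCc1ccc(OCC(=O)Cn2nnnc2C(=O)OC)cc1` gives 1000 nM in this assay.

Compound 3 stands at the highest number of the three, that is, it is the weakest inhibitor measured: the step of a 24-fold higher number from compound 1 to compound 3 (1.39 log units; beyond the scatter) and the step of an 18-fold higher number from compound 2 to compound 3 (1.26 log units; beyond the scatter) are both large and beyond the scatter, while the step of a 1.3-fold higher number from compound 1 to compound 2 (0.13 log units; within the scatter) stays within it. Compound 4 `CCCCCCCCc1ccc(OCC(=O)Cn2nnnc2C(=O)OCC)cc1` differs from compound 3 by one small change: methyl in place of hydrogen on a saturated chain carbon bound to an oxygen next to a carbonyl group. For the measured compounds named here, all three measured steps swap the whole group on the aromatic carbon of the shared core; none lengthens the ester itself, so no measured step bears directly on this change. Going by the values given here, the only guidance is that compound 3 already carries the group that brought the large loss, and adding one carbon to its alkoxy part is a much smaller alteration than those swaps. The step of no change at the digits printed from compound 3 to compound 4 (within the scatter) is therefore expected to stay within the scatter, in no clear direction. Compound 4 is estimated at 1000 nM, with a range from 400 nM to 2500 nM.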

Compound 4, half-maximal inhibitory concentration: 940 nM
The estimate for compound 4 lay 1.1-fold (0.03 log units) above the measured number; the range from low to high includes it.
By their numbers in this assay, from the lowest: compounds 1 and 2 (each within the scatter of the next); then compounds 4 and 3 (each within the scatter of the next).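

Adding methyl in place of hydrogen on a saturated chain carbon bound to an oxygen next to a carbonyl group, which turns methoxycarbonyl into ethoxycarbonyl, leaves the number in this assay within the scatter (a 1.1-fold lower number from compound 3 to compound 4 (0.03 log units; within the scatter)). The large loss is therefore not confined to methoxycarbonyl, as ethoxycarbonyl also sits far from both methyl (a 23-fold higher number from compound 1 to compound 4 (1.36 log units; beyond the scatter)) and thiophen-2-yl (a 17-fold higher number from compound 2 to compound 4 (1.23 log units; beyond the scatter)). Nothing measured here explains why these two esters sit so far from the methyl and thiophen-2-yl compounds.

The compounds shown leave open whether a longer alkoxy chain, such as butoxycarbonyl, would also stay within the scatter of compound 3. They also do not tell whether a carboxylic acid or a primary amide on this aromatic carbon would share the loss or recover the lower numbers.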